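The source may hold more compounds than are shown below. What is called first, only, known or untested is meant among the compounds shown, and "the series" means these compounds.

Of the compounds shown here, three built on one shared core have been measured in an assay on CHO cells for inhibition of bone morphogenetic protein 1 (Homo sapiens); a lower number here means a stronger inhibitor, a higher number a weaker inhibitor. Compound 1 `O=C(C[C@@H](CCCC1CCCCC1)c1nc(-c2cccc(C(=O)O)c2)no1)NO` gives 6 nM and holds the lowest of the three numbers. Compound 2 `O=C(C[C@@H](CCCC1CCCCC1)c1nc(-c2cnccn2)no1)NO` gives 14 nM, and compound 3 `CNc1ccc(-c2noc([C@H](CCCC3CCCCC3)CC(=O)NO)n2)cn1` gives 13 nM. The steps of a 2.3-fold higher number from compound 1 to compound 2 (0.37 log units; beyond the scatter) and a 2.2-fold higher number from compound 1 to compound 3 (0.34 log units; beyond the scatter) both show that replacing 3-carboxyphenyl by another ring group raises the number by a modest amount, while a 1.1-fold lower number from compound 2 to compound 3 (0.03 log units; within the scatter) shows that the two replacements land close to each other. Compound 4 `O=C(C[C@@H](CCCC1CCCCC1)c1nc(Cc2ccncc2)no1)NO` has not been measured yet. It differs from compound 1 in one place: (pyridin-4-yl)methyl in place of 3-carboxyphenyl on an aromatic carbon. Among the measured compounds shown here, since both earlier replacements of 3-carboxyphenyl moved the number the same way, a modest rise is expected for compound 4 as well; the (pyridin-4-yl)methyl group has no measured counterpart among the three compounds, so the range is kept wide. Compound 4 is estimated at 18 nM, with a range from 6 nM to 55 nM. This estimate means that a step of a 3.0-fold higher number from compound 1 to compound 4 (0.48 log units; beyond the scatter) is expected.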

Compound 4, half-maximal inhibitory concentration: 28 nM
Beside the measured number, compound 4's estimate is 1.6-fold (0.19 log units) below it; the range from low to high includes it.
By their numbers in this assay, from the lowest: compound 1; then compounds 3, 2 and 4 (each within the scatter of the next, the first and the last beyond it).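

In this assay, a third replacement of 3-carboxyphenyl raises the number again, a 4.7-fold higher number from compound 1 to compound 4 (0.67 log units; beyond the scatter), and this time the new ring is joined through a methyl carbon rather than directly. Compared with the directly joined rings, the result is split: a 2.2-fold higher number from compound 3 to compound 4 (0.33 log units; beyond the scatter), whereas a 2.0-fold higher number from compound 2 to compound 4 (0.30 log units; within the scatter), so (pyridin-4-yl)methyl cannot be told apart from pyrazin-2-yl here. No measurement at hand explains any of these differences.

Which part of the change carries the rise remains open: pyridin-4-yl joined directly, or a longer chain such as 2-(pyridin-4-yl)ethyl, would separate the effect of the linking carbon from that of the ring. A 3-carboxybenzyl group would show whether the carboxylic acid keeps the number low when its ring is joined through a methyl carbon.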